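Fluoro added to the core of compound 2

This account rests on a few compounds, and the source may have more. Where it says the series, first, only, none or still open, it means among the compounds named here.

Compound 2 `CCCc1cnc(N2CCC(C3Cc4cc(C5=CCN(S(=O)(=O)CCCO)CC5)cc(F)c4O3)CC2)nc1` gives 122 nM in a functional assay on HEK293 cells for agonist activity at Glucose-dependent insulinotropic receptor (Homo sapiens), read by cAMP accumulation, with a stated time of 60 min (a lower number here means that less compound is needed, a higher number that more compound is needed for the effect), and stands highest of the three measured numbers. Compound 3 `CCCc1cnc(N2CCC(C3Cc4cc(C5=CCN(S(=O)(=O)CCCCO)CC5)cc(F)c4O3)CC2)nc1` gives 60 nM in this assay, and compound 1 `CCCc1cnc(N2CCC(C3Cc4c(F)c(C5=CCN(S(=O)(=O)CCC)CC5)cc(F)c4O3)CC2)nc1` gives 2 nM. The step from compound 2 to compound 4 `CCCc1cnc(N2CCC(C3Cc4c(F)c(C5=CCN(S(=O)(=O)CCCO)CC5)cc(F)c4O3)CC2)nc1` is fluoro in place of hydrogen on an aromatic carbon. Within the data shown here, the only single-point step measured so far, a 2.0-fold lower number from compound 2 to compound 3 (0.31 log units; beyond the scatter), concerns the chain on the sulfonyl sulfur, not the aromatic ring, and so offers no direct guide. Compound 1 carries the same fluoro as compound 4 but differs from compound 2 in the sulfonyl chain as well, so its gap to compound 2 cannot be assigned to the fluoro alone; what the two values show is that the fluoro-bearing compound 1 sits far lower than compound 2. On that basis a lowering of the number is expected for compound 4, estimated as a 6.1-fold lower number from compound 2 to compound 4 (0.79 log units; beyond the scatter), with the size uncertain. Compound 4 is therefore expected to give about 20 nM in this assay, within roughly 5 nM to 80 nM.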

Compound 4, half-maximal effective concentration: 16 nM
For compound 4 the middle estimate is 1.3-fold (0.10 log units) above the measured one; the range from low to high includes it.
By their numbers in this assay, from the lowest: compound 1; then compound 4; then compound 3; then compound 2.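

In this assay, the fluoro on this aromatic carbon, para to a fluoro group, now has a size of its own with the sulfonyl chain held constant: a 7.6-fold lower number from compound 2 to compound 4 (0.88 log units; beyond the scatter). With this fluoro present in both compounds, hydroxy in place of hydrogen on the saturated chain carbon, three bonds along the chain from the sulfonyl sulfur, gives an 8.0-fold higher number from compound 1 to compound 4 (0.90 log units; beyond the scatter), so the chain end also moves the number and the two steps run in opposite directions. No measurement shown gives a reason for either step.

On these data alone, whether the hydroxy step keeps its size on the core without this fluoro stays open, as does whether the fluoro step holds with the chain of compound 3. Also open, as far as these compounds go, is how chloro, methyl or nitrile on this aromatic carbon, or a carboxylic acid or an amine at the chain end, would compare.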